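Methyl to methoxy on a shared hydrazide core

The compounds below may be only part of what the source reports. "The series", "measured", "known", "first", "only" and "open" are said of these compounds alone.

Compound 1, `CC(C)(C)N(NC(=O)c1ccccc1Br)C(=O)c1ccccc1Cl`, gives 316 nM in an assay on cells for agonist activity at ecdysone receptor (Bombyx mori), read by a luciferase reporter, with a stated time of 24 h; a higher number here means that more compound is needed for the effect, a lower number that less compound is needed. Compound 2, `CC(C)(C)N(NC(=O)c1ccc(I)cc1)C(=O)c1ccccc1Cl`, gives 7.59 nM in this assay. Compound 3, `Cc1ccc(C(=O)NN(C(=O)c2ccccc2Cl)C(C)(C)C)cc1`, gives 18.6 nM in this assay.

Among these three numbers compound 3 stands second. Its nearest neighbour is one modest step away: a 2.5-fold higher number from compound 2 to compound 3 (0.39 log units; beyond the scatter). Its furthest neighbour is a large step away: a 17-fold lower number from compound 1 to compound 3 (1.23 log units; beyond the scatter).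

Compound 4, `COc1ccc(C(=O)NN(C(=O)c2ccccc2Cl)C(C)(C)C)cc1`, differs from compound 3 in a single place: methoxy in place of methyl on an aromatic carbon. Among the compounds with values here, no measured pair exchanges methyl for methoxy, so the expectation must lean on neighbouring evidence. Within the data shown here, the one step that alters the same ring position is a 2.5-fold higher number from compound 2 to compound 3 (0.39 log units; beyond the scatter), and it is modest. The two large steps, a 42-fold lower number from compound 1 to compound 2 (1.62 log units; beyond the scatter) and a 17-fold lower number from compound 1 to compound 3 (1.23 log units; beyond the scatter), move the substituent from one ring position to another as well as changing its identity, so they speak less directly to a swap that keeps the position fixed. On this basis the change is expected to produce a small shift of a 1.5-fold higher number from compound 3 to compound 4 (0.18 log units; within the scatter), possibly not beyond the usual scatter, towards a slightly higher number. Compound 4 is therefore estimated at 28 nM, with a range from 8 nM to 90 nM.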

Compound 4, half-maximal effective concentration: 51.3 nM
Beside the measured number, compound 4's estimate is 1.8-fold (0.26 log units) below it; the measured number falls inside the stated range.
By their numbers in this assay, from the lowest: compound 2; then compound 3; then compound 4; then compound 1.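

Methyl and methoxy are not interchangeable on this aromatic carbon, para to a large group: in this assay the swap gives a 2.8-fold higher number from compound 3 to compound 4 (0.44 log units; beyond the scatter) and so counts as a real change, which the earlier compounds could not show. With methoxy as a third group at this position, the span among the groups there widens, with a 6.8-fold higher number from compound 2 to compound 4 (0.83 log units; beyond the scatter) as the largest step among them, and the order from the lowest number runs iodo, methyl, methoxy. The 4-methoxyphenyl group still keeps some of the advantage over 2-bromophenyl seen for the other two groups, with a 6.2-fold lower number from compound 1 to compound 4 (0.79 log units; beyond the scatter) as a smaller step than either earlier one from compound 1, so all three compounds with a group at this position have lower numbers than compound 1.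

The compounds shown leave open how a hydroxyl, an amine or a longer chain such as ethoxy would sit in this order, and whether the gap to compound 1 follows the position or the group, as none of them carries the same group at both places. Nothing among the data shown explains why methoxy gives a higher number than methyl.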